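The compounds below may be only part of what the source reports. "The series", "measured", "known", "first", "only" and "open" are said of these compounds alone.

Compound 1 `CCc1c(F)c(N)c2c(=O)cc(-c3ccc(N)c(F)c3)oc2c1F` carries an ethyl group on the aromatic carbon of its core. In a functional assay on HeLa cells (Homo sapiens) for cytotoxicity, read by neutral red uptake, with a stated time of 3 days (on this read-out lower numbers stand for stronger inhibition and higher numbers for weaker inhibition), compound 1 gives > 100000 nM, which is a limit of the assay and not a number. Compound 2 `Nc1ccc(-c2cc(=O)c3c(N)c(F)c(O)c(F)c3o2)cc1F` has a hydroxy at that carbon instead. In this assay compound 2 gives > 100000 nM, again a limit of the assay. The step that the two limits leave unreadable from compound 1 to compound 2 is therefore of no readable size. Compound 2 stands at the limit, the point at which both values shown sit (the limit of > 100000 nM in this assay, at which 2 of the 2 values shown sit); it has no number of its own.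

Compound 3 `[N-]=[N+]=Nc1c(F)c(N)c2c(=O)cc(-c3ccc(N)c(F)c3)oc2c1F` differs from compound 2 by azido in place of hydroxy on an aromatic carbon. Within the data shown here, the only measured step, a step that the two limits leave unreadable from compound 1 to compound 2, concerns the same carbon but is unreadable, so it supplies no size to carry over. No step beyond the scatter is expected in this assay, and the likeliest outcome is a further limit. Compound 3 is accordingly estimated at 150000 nM, with a range from 50000 nM to 500000 nM. For compound 3 the expected step is a step that the limit leaves unreadable from compound 2 to compound 3, nothing beyond the scatter.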

Compound 3, half-maximal inhibitory concentration: 1200 nM
Compound 3: the middle estimate sits 130-fold (2.10 log units) above what was measured, outside the stated range (below it).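

Azido in place of hydroxy on the aromatic carbon ortho to two fluoro groups gives an at least 83-fold lower number from compound 2 to compound 3 (1.92 log units; beyond the scatter) in this assay, so this position can move the read-out, which the earlier pair alone did not show. Azido in place of ethyl gives an at least 83-fold lower number from compound 1 to compound 3 (1.92 log units; beyond the scatter), so the lower number appears against both groups that leave, and compound 3 is the only compound shown with a value that is a number. Both sizes are lower bounds set by limits of the assay, and the step between compound 1 and compound 2 cannot be read, as both of their values are such limits: the limit of > 100000 nM in this assay, at which 2 of the 3 values shown sit.

The compounds shown leave open whether the lower number belongs to azido alone or also to other groups on this carbon, such as an amine, a nitrile or a methoxy group. Equally open, going by these compounds, is what the two fluoro groups ortho to this carbon contribute to the value of compound 3, a question that a hydrogen in place of either one would address.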